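This account rests on a few compounds, and the source may have more. Where it says the series, first, only, none or still open, it means among the compounds named here.

In an assay on CHO-K1 cells for displacement of a labelled ligand from prostaglandin E2 receptor EP1 subtype (Homo sapiens) (on this read-out higher numbers stand for weaker inhibition and lower numbers for stronger inhibition), compound 1 `Cc1cc(C(=O)Nc2ccc(F)cc2)nn1Cc1cc(Cl)ccc1OCc1ccccc1` gives 79.4 nM, and compound 2 `Cc1cc(C(=O)NCc2ccncc2)nn1Cc1cc(Cl)ccc1OCc1ccccc1` gives 79.4 nM; the step of no change at the digits printed from compound 1 to compound 2 (within the scatter) leaves the two level. Compound 3 `Cc1cc(NC(=O)C2CCOCC2)nn1Cc1cc(Cl)ccc1OCc1ccccc1` differs from compound 2 by ((oxan-4-yl)carbonyl)amino in place of ((pyridin-4-yl)methyl)carbamoyl on an aromatic carbon. Within the data shown here, no measured step covers such a change: the only known step, no change at the digits printed from compound 1 to compound 2 (within the scatter), replaced one group on an amide-type nitrogen without effect, whereas here a six-membered non-aromatic ring with 1 hetero atom enters and a six-membered aromatic ring with 1 hetero atom leaves. A modest weakening with wide uncertainty is therefore expected for compound 3, as a 2.5-fold higher number from compound 2 to compound 3 (0.40 log units; beyond the scatter). Compound 3 is estimated at 200 nM, between 50 nM and 800 nM.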

Compound 3, half-maximal inhibitory concentration: 63.1 nM
Compound 3: middle estimate off by 3.2-fold (0.50 log units), on the high side; low and high end bracket the measured number.
By their numbers in this assay, from the lowest: compounds 3, 1 and 2 (each within the scatter of the next).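

In this assay, placing ((oxan-4-yl)carbonyl)amino on this aromatic carbon gives a 1.3-fold lower number from compound 2 to compound 3 (0.10 log units; within the scatter) in place of ((pyridin-4-yl)methyl)carbamoyl, and a 1.3-fold lower number from compound 1 to compound 3 (0.10 log units; within the scatter) in place of (4-fluorophenyl)carbamoyl. The earlier step changed only the group on the amide nitrogen, whereas this position also tolerates a whole-group exchange that attaches the amide through its nitrogen and brings in a non-aromatic ring. Nothing measured explains this tolerance. On these data alone, whether a simple amine or a carboxylic acid on this carbon would hold the same level remains open.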